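Swapping a furan ring for isopropyl on a pyranone core

The source may hold more compounds than are shown below. What is called first, only, known or untested is meant among the compounds shown, and "the series" means these compounds.

Measured so far:
- compound 1 `CCCCCc1cc(Nc2ccc(OC)cc2)cc(=O)o1`: 10.1 uM
- compound 2 `COc1ccc(Nc2cc(-c3ccccc3)oc(=O)c2)cc1`: 0.16 uM
- compound 3 `COc1ccc(Nc2cc(-c3ccco3)oc(=O)c2)cc1`: 2.66 uM

These three compounds share a core and differ only in one group on an aromatic carbon. In a functional assay on KB cells (Homo sapiens) for cytotoxicity, read by MTT assay, with a stated time of 72 h (on this read-out lower numbers stand for an effect already at smaller amounts and higher numbers for an effect only at larger amounts of compound), compound 3 stands second highest of the three numbers: its nearest neighbour is compound 1, and the step of a 3.8-fold lower number from compound 1 to compound 3 (0.58 log units; beyond the scatter) is modest; its furthest is compound 2, and the step of a 17-fold higher number from compound 2 to compound 3 (1.22 log units; beyond the scatter) is large. The step of a 63-fold lower number from compound 1 to compound 2 (1.80 log units; beyond the scatter) is the largest of all.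

Compound 4 `COc1ccc(Nc2cc(C(C)C)oc(=O)c2)cc1` has not yet been measured. It differs from compound 3 in one place: isopropyl in place of furan-2-yl on an aromatic carbon.

Among the compounds with values here, the step that bears most directly on this change is the one from compound 1 to compound 3, in which a furan-2-yl ring replaced a pentyl chain and the number fell modestly. Compound 4 goes the other way, from a ring back to a chain, though isopropyl is a shorter chain than pentyl. The two ring-bearing compounds 2 and 3 both gave lower numbers than the chain-bearing compound 1, so the expected step of a 5.6-fold higher number from compound 3 to compound 4 (0.75 log units; beyond the scatter) in this assay is upward, roughly reversing the step from compound 1 to compound 3. The estimate for compound 4 is therefore 15 uM, with a range from 4 uM to 60 uM.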

Compound 4, concentration for half-maximal effect: > 30 uM
Compound 4 was reported as a limit; the forecaster's own chance of this, stated with the estimate: 10%; middle value at least 2.0-fold (0.30 log units) from the limit.
By their numbers in this assay, from the lowest: compound 2; then compound 3; then compound 1. At a limit, above all of these: compound 4.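

In this assay compound 4 gives > 30 uM which is a limit of the assay and not a number. Even with that limit, replacing a ring with isopropyl at this place, next to the ring oxygen of the shared core, gives an at least 11-fold higher number from compound 3 to compound 4 (1.05 log units; beyond the scatter) and an at least 180-fold higher number from compound 2 to compound 4 (2.27 log units; beyond the scatter) as two large steps, so both ring-bearing compounds now have lower numbers than both chain-bearing ones, and none of the four compounds goes against this. The earlier compounds shown here held only one chain, pentyl, and they could not show that the shorter isopropyl chain fails to bring the number down: the step is an at least 2.9-fold higher number from compound 1 to compound 4 (0.47 log units; beyond the scatter) in this assay as well.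

The compounds shown leave open how far past its limit compound 4 really lies, and so how large these steps truly are. They also leave open whether a ring as such is enough here, or whether it must be aromatic, which a cyclohexyl group could test, and whether a longer chain such as heptyl would continue the trend between the two chains.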